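Adding a methyl to the core of compound 1

The source may report more compounds than this note shows. Statements on the series, on what has been measured and on what is new or still open speak of the compounds shown alone.

In a functional assay on SK-MEL-5 cells (Homo sapiens) for antiproliferative activity (a higher number here means a weaker inhibitor of growth, a lower number a stronger inhibitor of growth), compound 1 `Cc1ccc2c(O)cc(-c3cccc(Cl)c3)nc2n1` gives 31.6 nM and compound 2 `Cc1cccc(-c2cc(O)c3ccc(C)nc3n2)c1` gives 126 nM. Compound 1 therefore holds the lower of the two numbers and is the stronger inhibitor of growth so far.

Compound 3 `Cc1cc(C)c2c(O)cc(-c3cccc(Cl)c3)nc2n1` keeps the chloro group of compound 1 and differs in one place: methyl in place of hydrogen on an aromatic carbon. This puts a methyl in place of hydrogen on an aromatic carbon, opposite the ring nitrogen and meta to a methyl group.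

Going by the values given here, only one measured step bears on this change, and only indirectly: a 4.0-fold higher number from compound 1 to compound 2 (0.60 log units; beyond the scatter). That step also brings in a methyl, but it replaces a chloro group elsewhere in the structure. Among the compounds with values here, no measured compound carries a group at the new place, so both direction and size remain uncertain.

A modest rise in the number is expected, no larger than that single step, although a change within the scatter remains possible. The expected step is a 2.2-fold higher number from compound 1 to compound 3 (0.35 log units; beyond the scatter).

For compound 3 the estimated value is 70 nM, with an expected range of 20 nM to 250 nM.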

Compound 3, concentration for 50% growth inhibition: 117 nM
The estimate for compound 3 lay 1.7-fold (0.22 log units) below the measured number, within the range that was stated.
By their numbers in this assay, from the lowest: compound 1; then compounds 3 and 2 (each within the scatter of the next).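

Going by these compounds alone, the methyl opposite the ring nitrogen is the first change to the core of compound 1 in this set, and in this assay it gives a 3.7-fold higher number from compound 1 to compound 3 (0.57 log units; beyond the scatter) with the chloro group kept. This position is therefore not indifferent to substitution: adding a single methyl to an aromatic carbon that bore only hydrogen is enough to weaken growth inhibition beyond the scatter, so the core as well as the chloro group matters, as a 4.0-fold higher number from compound 1 to compound 2 (0.60 log units; beyond the scatter) showed for that group. No measurement on these compounds accounts for the loss.

As far as these compounds go, whether any group at this place costs activity or the loss is specific to methyl stays open, and a fluoro, methoxy or amino group there would help separate those two readings. Within the data shown here, also open is whether the change adds to the one at the chloro group, which a compound carrying the new core methyl together with methyl in place of chloro would test.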